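Methoxy addition on the aryl ketone side of a chalcone series

The source may hold more compounds than are shown below. What is called first, only, known or untested is meant among the compounds shown, and "the series" means these compounds.

Measured so far in a functional assay on A498 cells (Homo sapiens) for cytotoxicity, read by sulforhodamine B assay, with a stated time of 48 h, tested at 1 uM; on this read-out higher numbers stand for a weaker effect at the one concentration tested and lower numbers for a stronger effect:
compound 1 `COc1ccc(-c2cc(/C=C/C(=O)c3ccc(N)cc3)[nH]n2)cc1`: 90%
compound 2 `COc1ccc(C(=O)/C=C/c2cc(-c3cc(OC)c(OC)c(OC)c3)n[nH]2)cc1OC`: 78%
compound 3 `COc1ccc(-c2cc(/C=C/C(=O)c3ccc(N)cc3)[nH]n2)cc1OC`: 89%

Compound 1 and compound 3 differ in one place, (methoxy in place of hydrogen on an aromatic carbon). Between them the step is a number 1 percentage points lower from compound 1 to compound 3 (within the scatter), so the added methoxy made no difference that can be told from repeat scatter. Compound 2 stands apart from both: in this assay compound 2 gives 78%, the lowest of the three numbers, and its gaps to compound 3 and to compound 1 both lie beyond the scatter, so among these three compound 2 shows the strongest effect at the single concentration tested. How the core of compound 2 differs from the core of compound 1 is not broken down here.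

Compound 4 `COc1cc(C(=O)/C=C/c2cc(-c3cc(OC)c(OC)c(OC)c3)n[nH]2)cc(OC)c1OC` has not yet been measured. It differs from compound 2 by methoxy in place of hydrogen on an aromatic carbon, which is the same kind of change as from compound 1 to compound 3, not the same: in compound 4 the entering methoxy is also meta to a methoxy group, a feature the earlier place lacks. In this assay, for the measured compounds named here, the step from compound 2 to compound 4 is expected to be a number 3 percentage points lower from compound 2 to compound 4 (within the scatter), small because a number 1 percentage points lower from compound 1 to compound 3 (within the scatter) was within the scatter for the one comparable pair. Compound 4 is therefore estimated at 75%, with a range from 58% to 90%. One pair is a thin basis, and the different surroundings of the new methoxy keep the range wide.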

Compound 4, a percentage reported as activity, at one concentration (the size of the read-out at that concentration, not a potency): 80%
Compound 4: the middle estimate sits 5 percentage points below what was measured; low and high end bracket the measured number.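

In this assay, for the compounds shown here, methoxy in place of hydrogen on an aromatic carbon again gives no step that can be told from repeat scatter, with a number 2 percentage points higher from compound 2 to compound 4 (within the scatter). Set beside the earlier pair, the change reads alike on the two cores, and no dependence on the core can be seen: the same change on two cores in this assay, a number 1 percentage points lower (within the scatter) from compound 1 to compound 3 and a number 2 percentage points higher (within the scatter) from compound 2 to compound 4, 3 percentage points apart, within the scatter of two such steps

This supports only a narrow statement: at the single concentration tested, in these two pairs, adding the methoxy leaves the read-out within the scatter. It does not show that the change is neutral on other cores or at other places, since it rests on two pairs, and in compound 4 the entering methoxy sits ortho to a methoxy group and meta to a methoxy group, surroundings the earlier place lacks.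

The compounds shown leave open whether another group at this place, such as hydroxy, ethoxy or a carboxylic acid, would give a step beyond the scatter. Also open, on these data alone, is whether the methoxy step would stay this small at concentrations other than the single one tested.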